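A few compounds are considered here, and "the series" means these few. Any claim that something is new, unique, unknown or untested is made for them only; others in the source may bear on it.

Measured so far: compound 1 `Cc1ccc2nc(C(=O)Nc3c(F)cc(-c4cccc(F)c4)cc3F)c(C)c(O)c2c1` with 11.2% and compound 2 `CCc1ccc2nc(C(=O)Nc3c(F)cc(-c4cccc(F)c4)cc3F)c(C)c(O)c2c1` with 23.5% in this assay.

In a functional assay on Hep 3B2 cells (Homo sapiens) for antiproliferative activity, read by MTT assay, with a stated time of 24 h, tested at 1.23 ug/mL (on this read-out lower numbers stand for a weaker effect and higher numbers for a stronger effect at the one concentration tested), compound 2 gives 23.5% and stands highest of the two numbers, while compound 1 gives 11.2% in this assay. Among the measured compounds shown here, the only measured step is a number 12.3 percentage points higher from compound 1 to compound 2 (beyond the scatter) and it concerns the very ethyl that is now exchanged. Compound 3 `Cc1c(C(=O)Nc2c(F)cc(-c3cccc(F)c3)cc2F)nc2ccc(F)cc2c1O` differs from compound 2 by fluoro in place of ethyl on an aromatic carbon. Fluoro is as far from the ethyl of compound 2 as the methyl of compound 1 was, so a modest fall toward compound 1 is expected, though the direction is uncertain. Compound 3 is expected to give 14% in this assay, ranging from 3% to 28%. This means an expected step of a number 9.5 percentage points lower from compound 2 to compound 3 (within the scatter) in this assay.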

Compound 3, a percentage reported as inhibition, at one concentration (the size of the read-out at that concentration, not a potency): 15.3%
For compound 3 the middle estimate is 1.3 percentage points below the measured one, within the range that was stated.
By their numbers in this assay, from the lowest: compounds 1, 3 and 2 (each within the scatter of the next, the first and the last beyond it).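

In this assay, the position now carries a group that is not an alkyl chain, and the result is a number 8.2 percentage points lower from compound 2 to compound 3 (within the scatter) and also a number 4.1 percentage points higher from compound 1 to compound 3 (within the scatter) in the same series. Fluoro therefore cannot be told apart from either ethyl or methyl here, even though ethyl and methyl lie beyond the scatter of each other. Nothing available explains this result. Still open, on these data alone, is what a longer chain, a methoxy group or an amine on this aromatic carbon would give.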